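Swapping the phenyl of compound 1 for a methylpyrrole

The source may hold more compounds than are shown below. What is called first, only, known or untested is meant among the compounds shown, and "the series" means these compounds.

Measured compounds:
- compound 1 `O=C(/C=C/c1ccc2c(c1)B(O)OC2)c1ccccc1`: 6100 nM
- compound 2 `O=C(/C=C/c1ccc2c(c1)B(O)OC2)c1ccco1`: 24100 nM
- compound 3 `O=C(/C=C/c1ccc2c(c1)B(O)OC2)c1cccnc1`: 20500 nM

All three share one core and differ only in the ring attached to the carbonyl carbon. In a functional assay on HCT-116 cells (Homo sapiens) for cytotoxicity, read by MTT assay, with a stated time of 48 h (on this read-out higher numbers stand for weaker inhibition and lower numbers for stronger inhibition), compound 1 gives the lowest number of the three. The other two sit clearly higher: a 4.0-fold higher number from compound 1 to compound 2 (0.60 log units; beyond the scatter) and a 3.4-fold higher number from compound 1 to compound 3 (0.53 log units; beyond the scatter), both modest but beyond the scatter. Between compound 2 and compound 3 the difference is a 1.2-fold lower number from compound 2 to compound 3 (0.07 log units; within the scatter), which is within the scatter.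

Compound 4 `Cn1cccc1C(=O)/C=C/c1ccc2c(c1)B(O)OC2` has not yet been measured. Compared with compound 1 the change is 1-methyl-1H-pyrrol-2-yl in place of phenyl on a carbonyl carbon. The two steps that bear on it are the ones that also replace phenyl by an aromatic ring holding one hetero atom, from compound 1 to compound 2 and from compound 1 to compound 3. Both moved the number up by a modest amount. Among the measured compounds shown here, a similar weakening is therefore expected here, as a 2.6-fold higher number from compound 1 to compound 4 (0.42 log units; beyond the scatter), although with only two such steps to go on the size is uncertain. For compound 4 the estimate in this assay is 16000 nM, with a range from 5000 nM to 45000 nM.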

Compound 4, half-maximal inhibitory concentration: > 100000 nM
Compound 4: no number, only a limit (the forecaster's own chance of this, stated with the estimate: 5%); middle value at least 6.2-fold (0.79 log units) from the limit.
By their numbers in this assay, from the lowest: compound 1; then compounds 3 and 2 (each within the scatter of the next). At a limit, above all of these: compound 4.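

In this assay, compound 4 gives only a limit of the assay and not a number: the limit of > 100000 nM in this assay, at which 1 of the 4 values shown sits. This shows that the place on the carbonyl carbon is far less forgiving than the earlier swaps suggested, even though phenyl and 1-methyl-1H-pyrrol-2-yl both hold 6 heavy atoms: the change gives an at least 16-fold higher number from compound 1 to compound 4 (1.21 log units; beyond the scatter), and compound 4 also stands apart from the two other compounds with a hetero atom in this ring, with an at least 4.1-fold higher number from compound 2 to compound 4 (0.61 log units; beyond the scatter) and an at least 4.8-fold higher number from compound 3 to compound 4 (0.68 log units; beyond the scatter). Ring size and the count of hetero atoms therefore do not settle the outcome on their own, as compound 2, whose furan-2-yl is also a five-membered aromatic ring with one hetero atom, still gives 24100 nM.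

The compounds shown do not separate the methyl group on the ring nitrogen from the pyrrole ring itself as the source of this loss. A pyrrol-2-yl ring without the methyl, or a phenyl ring carrying a methyl group or an amine, would be needed to tell these apart.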